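The source may hold more compounds than are shown below. What is called first, only, known or untested is meant among the compounds shown, and "the series" means these compounds.

Series notes. Compound 1 `CCN1CCN(Cc2ccc(NC(=O)c3ccc(C)c(-c4ccc5nc(NC(=O)C6CC6)sc5n4)c3)cc2C(F)(F)F)CC1` and compound 3 `CCN1CCN(Cc2ccc(NC(=O)c3ccc(F)c(-c4ccc5nc(NC(=O)C6CC6)sc5n4)c3)cc2C(F)(F)F)CC1` share one core and differ at a single point: fluoro in place of methyl on an aromatic carbon. In an ADME assay on BaF3 cells (Mus musculus) for cytotoxicity (on this read-out higher numbers stand for an effect only at larger amounts of compound and lower numbers for an effect already at smaller amounts), compound 1 gives 1230 nM. For compound 3 the reading in this assay is a limit of the assay, > 10000 nM, not a number. The step of an at least 8.1-fold higher number from compound 1 to compound 3 (0.91 log units; beyond the scatter) is thus bounded only from below, which follows from the limit of > 10000 nM in this assay, at which 1 of the 3 values shown sits. Compound 2 `Cc1cn(-c2cc(NC(=O)c3ccc(C)c(-c4ccc5nc(NC(=O)C6CC6)sc5n4)c3)cc(C(F)(F)F)c2)cn1` carries a second core; how that core differs from the core of compound 1 is not broken down here. In this assay compound 2 gives 4670 nM, higher than compound 1. Compound 4 `Cc1cn(-c2cc(NC(=O)c3ccc(F)c(-c4ccc5nc(NC(=O)C6CC6)sc5n4)c3)cc(C(F)(F)F)c2)cn1` stands to compound 2 as compound 3 stands to compound 1: fluoro in place of methyl on an aromatic carbon, the same change at the same place. The same kind of step as an at least 8.1-fold higher number from compound 1 to compound 3 (0.91 log units; beyond the scatter) is expected for compound 4, namely a 4.3-fold higher number from compound 2 to compound 4 (0.63 log units; beyond the scatter), resting on the identical change and on compound 2 starting from 4670 nM. Compound 4 is expected near 20000 nM, plausibly between 8000 nM and 60000 nM, with a real chance that only a limit is returned.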

Compound 4, half-maximal effective concentration: > 10000 nM
Compound 4: only a limit was reported (the forecaster's own chance of this, stated with the estimate: 70%); the middle value is on the limit's open side.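

In this assay, fluoro in place of methyl on an aromatic carbon moves the reading in the same direction on both cores, and on the second core this appears as an at least 2.1-fold higher number from compound 2 to compound 4 (0.33 log units; beyond the scatter): the same change on two cores in this assay, an at least 8.1-fold higher number (0.91 log units; beyond the scatter) from compound 1 to compound 3 and an at least 2.1-fold higher number (0.33 log units; beyond the scatter) from compound 2 to compound 4; the limit leaves it open whether they differ Compound 4 reads > 10000 nM, which is a limit of the assay and not a number, so this step has a lower bound only. The direction therefore carries from the core of compound 1 to the core of compound 2 across these two pairs, but whether the size of the step also carries cannot be read: the limit of > 10000 nM in this assay, at which 2 of the 4 values shown sit.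

The compounds shown leave open whether a chloro, a methoxy or a nitrile on the same aromatic carbon would shift the reading in the same direction as fluoro. They also leave open whether the methyl-to-fluoro step would keep its direction on a third core, since the pattern rests on two pairs alone.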